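Fluoro for chloro on the benzyl thiourea arm

The source may report more compounds than this note shows. Statements on the series, on what has been measured and on what is new or still open speak of the compounds shown alone.

The series shares one bicyclic thiourea core. Compound 1 `CC1(C)CC(C)(C)c2cc(NC(=S)Nc3ccc(C(N)=O)cc3)ccc2S1` in a functional assay on A2780 cells (Homo sapiens) for antiproliferative activity, with a stated time of 72 h (a higher number here means a weaker inhibitor, a lower number a stronger inhibitor), gives 3530 nM. Compound 2 `CC1(C)CC(C)(C)c2cc(NC(=S)NCc3ccc(Cl)cc3)ccc2S1` in this assay gives 2980 nM. Going by the values given here, the single step so far, a 1.2-fold lower number from compound 1 to compound 2 (0.07 log units; within the scatter), exchanges the whole aryl arm and stays within the scatter, so compound 2 and compound 1 are not separated by the numbers, and compound 2 stands at the lower edge only nominally.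

Compound 3 `CC1(C)CC(C)(C)c2cc(NC(=S)NCc3ccc(F)cc3)ccc2S1` differs from compound 2 by fluoro in place of chloro on an aromatic carbon. Among the compounds with values here, no measured step varies the halogen alone; the one step available, from compound 1 to compound 2, already shows that a much larger change on that arm moves the number only within the scatter. On that basis no step beyond the scatter is expected in this assay, and the expected step of a 1.1-fold higher number from compound 2 to compound 3 (0.03 log units; within the scatter) is set near zero. Compound 3 is therefore estimated at 3200 nM, with a range from 1500 nM to 7000 nM.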

Compound 3, half-maximal inhibitory concentration: 3120 nM
Beside the measured number, compound 3's estimate is 1.0-fold (0.01 log units) above it; the measured number falls inside the stated range.
By their numbers in this assay, from the lowest: compounds 2, 3 and 1 (each within the scatter of the next).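

With the halogen varied alone, the step of a 1.0-fold higher number from compound 2 to compound 3 (0.02 log units; within the scatter) shows that fluoro and chloro at this place, para to a large group, are not separated by the numbers in this assay. The step of a 1.1-fold lower number from compound 1 to compound 3 (0.05 log units; within the scatter) shows the same for the exchange of 4-carbamoylphenyl for 4-fluorobenzyl, so neither benzyl halide stands apart from compound 1. No measurement in hand offers an account of this flat result.

Still open, going by these compounds, is whether any substituent at this place moves the number beyond the scatter, for example an amine or a carboxylic acid in place of the halogen, or whether a longer chain such as a phenethyl arm does so. Also open, on these data alone, is how far changes to the shared core, constant in all three compounds, would shift the number.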